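The source may hold more compounds than are shown below. What is called first, only, known or untested is meant among the compounds shown, and "the series" means these compounds.

In an assay on liver for binding affinity to Alpha-1A adrenergic receptor (Homo sapiens), using microsomes (a higher number here means a weaker inhibitor, a lower number a stronger inhibitor), the measured compounds stand as follows:

compound 1 `CCC1=C(C(N)=O)C(c2ccc(F)cc2F)N(C(=O)NCCCN2CCN(c3ccccc3C(N)=O)CC2)C(=O)N1`: 1.3 nM
compound 2 `COC(=O)C1=C(C)NC(=O)N(C(=O)NCCCN2CCN(c3ccc(Cl)cc3)CC2)C1c1ccc(F)c(F)c1`: 0.8 nM
compound 3 `COCC1=C(C(=O)OC)C(c2cc(F)c(F)cc2F)N(C(=O)NCCCN2CCN(c3ccccc3C(N)=O)CC2)C(=O)N1`: 0.1 nM

Compound 2 has the second highest of the three numbers. Its nearest neighbour is compound 1, whose number is higher by an amount that lies within the scatter, so the two cannot be told apart. Compound 3 lies furthest away, with a lower number that is beyond the scatter; compound 3 is therefore the only one of the three that is clearly stronger than compound 2.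

Compound 4 `COC(=O)C1=C(C)NC(=O)N(C(=O)NCCCN2CCN(c3ccccc3Cl)CC2)C1c1ccc(F)c(F)c1` has not been measured. It differs from compound 2 only in 2-chlorophenyl in place of 4-chlorophenyl on an amine nitrogen in a ring. For the measured compounds named here, no pair of measured compounds isolates this change, so the size of the step cannot be read from the set. Compounds 1 and 3 carry a different substituted phenyl on the same ring nitrogen and both give low numbers, but they differ from compound 2 in other places as well, so they give no direct guide. For compound 4 the step from compound 2 is expected to be a 1.3-fold higher number from compound 2 to compound 4 (0.10 log units; within the scatter), that is, no change beyond the scatter. Compound 4 is therefore estimated at 1 nM in this assay, with a range from 0.3 nM to 3 nM.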

Compound 4, inhibition constant: 0.2 nM
Compound 4: middle estimate off by 5.0-fold (0.70 log units), on the high side; the whole stated range lies above it.
By their numbers in this assay, from the lowest: compounds 3 and 4 (each within the scatter of the next); then compounds 2 and 1 (each within the scatter of the next).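

In this assay, for the compounds shown here, this is the first direct reading of the substituent on the amine nitrogen in the ring: 2-chlorophenyl in place of 4-chlorophenyl gives a 4.0-fold lower number from compound 2 to compound 4 (0.60 log units; beyond the scatter), a step beyond the scatter, though modest. The two groups have the same atoms and the same counts under the comparison, so the number at this place responds to where the chlorine stands on the phenyl ring and not only to which atoms are present. No measured property in hand accounts for this step, so the result stands as an observation without an explanation.

Going by these compounds alone, whether the same change would give a similar step on the cores of compound 1 and compound 3 cannot be read, since no pair isolates it there. Also open, on these data alone, is how far the lower number depends on chlorine itself, which 2-bromophenyl, 2-methoxyphenyl or an unsubstituted phenyl at this place would help to settle.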